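A few compounds are considered here, and "the series" means these few. Any claim that something is new, unique, unknown or untested is made for them only; others in the source may bear on it.

Going by the values given here, in a functional assay on HeLa cells (Homo sapiens) for inhibition, with a stated time of 72 h (on this read-out lower numbers stand for an effect already at smaller amounts and higher numbers for an effect only at larger amounts of compound), three compounds have numbers so far. Compound 1 `COc1cc(CNCc2ccccc2)ccc1OCc1ccc(Cl)nc1` gives 90000 nM, compound 2 `COc1cc(CNCc2ccncc2)ccc1OCc1ccc(F)cc1` gives 6400 nM, and compound 3 `CCOc1cc(CNCc2ccncc2)ccc1OCc1ccc(Cl)cc1` gives 2500 nM. Compound 2 thus stands second highest of the three: its nearest neighbour is compound 3, whose number is lower by a margin beyond the usual scatter, while compound 1 lies much further away with a clearly higher number. Compound 4 `COc1cc(CNCc2ccncc2)ccc1OCc1ccc(C)cc1` has not been measured. It differs from compound 2 in a single place: methyl in place of fluoro on an aromatic carbon. Among the compounds with values here, no measured pair differs in only this way, so the data give no direct size for this step. In this assay the step is expected to be modest, a 1.4-fold lower number from compound 2 to compound 4 (0.15 log units; within the scatter), not clearly beyond the scatter. Compound 4 is expected to give 4500 nM, within a range from 1500 nM to 14000 nM.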

Compound 4, half-maximal effective concentration: 5000 nM
Compound 4: the middle estimate sits 1.1-fold (0.05 log units) below what was measured; low and high end bracket the measured number.
By their numbers in this assay, from the lowest: compounds 3, 4 and 2 (each within the scatter of the next, the first and the last beyond it); then compound 1.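

In this assay, going by these compounds alone, methyl in place of fluoro on the aromatic carbon para to a large group gives a 1.3-fold lower number from compound 2 to compound 4 (0.11 log units; within the scatter) and so offers the first direct reading at this position. Within the usual scatter, the 4-fluorobenzyl and 4-methylbenzyl compounds cannot be told apart. No measurement at hand explains this result. Only these two small groups can be compared directly at this position. On these data alone, whether an amine, a carboxylic acid or a longer chain such as butyl would read the same there remains open.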